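This account rests on a few compounds, and the source may have more. Where it says the series, first, only, none or still open, it means among the compounds named here.

In a functional assay on MDA-MB-435 cells (Homo sapiens) for cytotoxicity, read by MTT assay, with a stated time of 72 h (on this read-out lower numbers stand for stronger inhibition and higher numbers for weaker inhibition), compound 1 (`CN(C)CCCNc1c(C(=O)NCc2ccc(F)cc2)nc(Br)c2cccnc12`) gives 7000 nM. Compound 2 (`CNc1c(C(=O)NCc2ccc(F)cc2)nc(Br)c2cccnc12`) gives > 20000 nM, which is a limit of the assay. Compound 3 (`NCCCCCCNc1c(C(=O)NCc2ccc(F)cc2)nc(Br)c2cccnc12`) has 5-aminopentyl in place of hydrogen on a saturated chain carbon bound to a nitrogen on an aromatic ring. Going by the values given here, one measured step bears on this, an at least 2.8-fold higher number from compound 1 to compound 2 (0.45 log units; beyond the scatter), where hydrogen replaced 2-(dimethylamino)ethyl. Restoring a chain ending in an amine should therefore lower the number in this assay, and the expected change is an at least 5.0-fold lower number from compound 2 to compound 3 (0.69 log units; beyond the scatter). Compound 3 is estimated at 4000 nM, with an expected range of 1000 nM to 15000 nM.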

Compound 3, half-maximal inhibitory concentration: 6000 nM
The estimate for compound 3 lay 1.5-fold (0.18 log units) below the measured number; low and high end bracket the measured number.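

In this assay the step from methyl to 6-aminohexyl gives an at least 3.3-fold lower number from compound 2 to compound 3 (0.52 log units; beyond the scatter) and shows that this position accepts a long chain ending in a primary amine. Compound 2 sits at a limit, so that step is a bound and not a size: the limit of > 20000 nM in this assay, at which 1 of the 3 values shown sits. The hexyl chain with its primary amine and the propyl chain with its dimethylamino end give a 1.2-fold lower number from compound 1 to compound 3 (0.07 log units; within the scatter) and cannot be told apart here.

On these data alone, whether the amine or the chain itself carries the step stays open. A plain hexyl chain or a carboxylic acid at the chain end would separate the two.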